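The source may report more compounds than this note shows. Statements on the series, on what has been measured and on what is new or still open speak of the compounds shown alone.

In an ADME assay on MT2 cells (Homo sapiens) for cytotoxicity, read by XTT assay, with a stated time of 4 days (a lower number here means that less compound is tolerated, a higher number that more compound is tolerated), compound 1 `Cc1cc(Br)cc(C)c1Oc1ccc([N+](=O)[O-])c(Nc2ccc(C#N)cc2)n1` gives 65100 nM, while compound 2 `Cc1cc(Br)cc(C)c1Oc1ccc(N)c(Nc2ccc(C#N)cc2)n1` gives 9610 nM, the lower of the two numbers. Compound 3 `CC(=O)CCc1cc(C)c(Oc2ccc(N)c(Nc3ccc(C#N)cc3)n2)c(C)c1` differs from compound 2 in one place: 2-acetylethyl in place of bromo on an aromatic carbon, with 2-acetylethyl in place of bromo on an aromatic carbon. Among the measured compounds shown here, the only measured step, a 6.8-fold lower number from compound 1 to compound 2 (0.83 log units; beyond the scatter), is a different change, amino in place of nitro, so it shows what size of step can occur here but gives no direction for this one. The expected step in this assay is therefore a 1.2-fold higher number from compound 2 to compound 3 (0.10 log units; within the scatter), not beyond the scatter. For compound 3 the estimated value is 12000 nM, within an expected range of 4500 nM to 35000 nM.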

Compound 3, half-maximal cytotoxic concentration: 18400 nM
Estimate against measurement, compound 3: 1.5-fold (0.19 log units) below; low and high end bracket the measured number.
By their numbers in this assay, from the lowest: compounds 2 and 3 (each within the scatter of the next); then compound 1.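

In this assay, a 1.9-fold higher number from compound 2 to compound 3 (0.28 log units; within the scatter) shows that this position, para to a large group and meta to two methyl groups, accepts 2-acetylethyl, with 5 heavy atoms, in place of bromo, with 1, without a step beyond the scatter. The earlier step concerned a different place on the molecule and said nothing about this one. No evidence on the cause of this result is available. From the compounds shown here alone, whether an amine, a carboxylic acid or a longer chain at this position would also stay within the scatter remains open.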